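Phenyl in place of hydrogen on the shared core

The source may report more compounds than this note shows. Statements on the series, on what has been measured and on what is new or still open speak of the compounds shown alone.

Compound 3 `CCc1nc(C)c2cnnc(O)n12` stands at the floor of a functional assay for inhibition, with Homo sapiens as the target; a lower number here means a stronger inhibitor, a higher number a weaker inhibitor: in this assay compound 3 gives > 48000 nM, a limit and not a number. Compound 2 `CCc1nnc(O)n2c(CC)nc(C)c12` gives 24000 nM in this assay. Within the data shown here, the only step joining two measured compounds runs an at least 2.0-fold higher number from compound 2 to compound 3 (0.30 log units; that floor lies within the scatter). Compound 1 `Cc1nc(C(C)C)n2c(O)nnc(-c3ccccc3)c12` also gives a limit, > 48000 nM in this assay. The floor of the series is the limit of > 48000 nM in this assay, at which 2 of the 3 values shown sit, so the numbers show little beyond it.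

Compound 4 `CCc1nc(C)c2c(-c3ccccc3)nnc(O)n12` differs from compound 3 by phenyl in place of hydrogen on an aromatic carbon. Among the measured compounds shown here, no measured step covers a phenyl entering at this place; the step from compound 2 to compound 3 concerns an ethyl leaving, not a phenyl entering. Compound 1 carries a phenyl on its core and its value is a limit. Nothing in the numbers therefore points to a step beyond the scatter in this assay, in either direction. Compound 4 is expected to give 60000 nM, within 30000 nM to 150000 nM, an estimated step that the limit leaves unreadable from compound 3 to compound 4. Most likely this assay reports only a limit for compound 4.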

Compound 4, half-maximal inhibitory concentration: > 48000 nM
Compound 4 ended at the assay's limit (the forecaster's own chance of this, stated with the estimate: 75%); the middle value does not contradict the limit.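

Phenyl in place of hydrogen on this aromatic carbon, para to a hydroxy group, leaves the compound at the floor of the series, so a six-membered aromatic ring of carbon at this place gives no value inside the range of this assay: the limit of > 48000 nM in this assay, at which 3 of the 4 values shown sit. The steps from compound 3 and from compound 1 to compound 4 cannot be read, as limits stand at both ends. Among these compounds, the one readable step is an at least 2.0-fold higher number from compound 2 to compound 4 (0.30 log units; that floor lies within the scatter), and compound 2 remains the only compound with a number.

As far as these compounds go, whether an amine or a carboxylic acid on this aromatic carbon would give a number rather than a limit remains open. Also open, from the compounds shown here alone, is whether a longer chain at this place would bring a value back inside the range of this assay.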